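Replacing an oxopiperidinyl with a piperidinyl on a shared core

This account rests on a few compounds, and the source may have more. Where it says the series, first, only, none or still open, it means among the compounds named here.

Of the compounds shown here, three have so far been measured in an ADME assay on a cell-free system (plasma, Mus musculus) for metabolic stability, read by LC-MS, tested at 2 uM; a lower number here means that the compound disappears faster, a higher number that the compound lasts longer. Compound 1 `CC(C)CNC(=O)n1c(=O)oc2c(C3CCN(C)CC3)cccc21` gives 0.667 h, compound 2 `CC(C)CNC(=O)n1c(=O)oc2cc(C3CCCCN3C)ccc21` gives 0.5 h, and compound 3 `CN1CCC(c2ccc3c(c2)oc(=O)n3C(=O)NCCCCc2ccccc2)CC1=O` gives 0.6 h. Compound 3 stands second among these three numbers, yet its nearest neighbour compound 1 and its furthest neighbour compound 2 both lie within the scatter of this assay, so the three values cannot be told apart.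

Compound 4 `CN1CCC(c2ccc3c(c2)oc(=O)n3C(=O)NCCCCc2ccccc2)CC1` has not yet been measured. It differs from compound 3 in a single place: 1-methylpiperidin-4-yl in place of 1-methyl-2-oxopiperidin-4-yl on an aromatic carbon. Going by the values given here, no pair of measured compounds differs in exactly one place, so the size of this kind of step has not been observed directly. The three measured values cluster closely, and the account therefore expects no step beyond the scatter from compound 3 to compound 4, namely no change at the digits printed from compound 3 to compound 4 (within the scatter). In this assay compound 4 is estimated at 0.6 h, with a range from 0.3 h to 1.2 h.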

Compound 4, half-life: 0.833 h
Compound 4: the middle estimate sits 1.4-fold (0.14 log units) below what was measured; the measured number falls inside the stated range.
By their numbers in this assay, from the lowest: compounds 2, 3, 1 and 4 (each within the scatter of the next).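

In this assay, the exchange of 1-methyl-2-oxopiperidin-4-yl for 1-methylpiperidin-4-yl on this aromatic carbon gives the first step seen directly between two compounds differing in one place: a 1.4-fold higher number from compound 3 to compound 4 (0.14 log units; within the scatter). Going by these compounds alone, the carbonyl on the piperidine ring can therefore be lost here without a step beyond the scatter, which the earlier compounds, none of them a single-place pair, could not show. Nothing available explains this result or links it to a property of either group.

From the compounds shown here alone, whether a morpholine, an open-chain amine or a carboxylic acid on this aromatic carbon would stay within the scatter remains open. Going by these compounds, it is also open whether the same exchange would give a step of similar size on a core carrying a shorter chain.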